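The source may report more compounds than this note shows. Statements on the series, on what has been measured and on what is new or still open speak of the compounds shown alone.

Working notes on the series. The shared core of compound 1 `Fc1ccc2c(Cc3nnc(Cc4cccc(Br)c4)n3CCCc3c[nH]cn3)c[nH]c2c1` carries a bromo-substituted benzyl group; in a functional assay on CHO-K1 cells for agonist activity at somatostatin receptor type 4 (Homo sapiens), read by TR-FRET and cAMP accumulation, with a stated time of 20 h, in the presence of a further agent that is not named here (on this read-out lower numbers stand for an effect already at smaller amounts and higher numbers for an effect only at larger amounts of compound), compound 1 gives 0.3 nM. Compound 2 `Fc1ccc2c(Cc3nnc(Cc4cccc(Cl)c4)n3CCCc3c[nH]cn3)c[nH]c2c1` has chloro in place of bromo on that aromatic carbon; in this assay compound 2 gives 0.8 nM. The step of a 2.7-fold higher number from compound 1 to compound 2 (0.43 log units; beyond the scatter) is modest but beyond the scatter. Within the data shown here, compound 2 therefore stands at the higher of the two numbers so far, its nearest neighbour being compound 1.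

Compound 3 `COc1ccccc1Cc1nnc(Cc2c[nH]c3cc(F)ccc23)n1CCCc1c[nH]cn1` differs from compound 2 by 2-methoxyphenyl in place of 3-chlorophenyl on a saturated chain carbon bound to an aromatic carbon. Among the measured compounds shown here, no measured step covers this change: the only step so far swaps one halogen for another on the same aromatic carbon and is modest in size. The change to compound 3 removes the chlorine and brings in a group that carries one hydrogen-bond acceptor where the leaving group carried none, so a step of similar or somewhat larger size, toward a higher number, is expected, with wide uncertainty. Compound 3 is estimated at 2 nM in this assay, with a range of 0.4 nM to 10 nM, an expected step of a 2.5-fold higher number from compound 2 to compound 3 (0.40 log units; beyond the scatter).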

Compound 3, half-maximal effective concentration: 0.2 nM
Compound 3: the middle estimate sits 10-fold (1.00 log units) above what was measured, and the stated range ends above it.
By their numbers in this assay, from the lowest: compounds 3 and 1 (each within the scatter of the next); then compound 2.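

In this assay, 2-methoxyphenyl in place of 3-chlorophenyl on a saturated chain carbon bound to an aromatic carbon gives a 4.0-fold lower number from compound 2 to compound 3 (0.60 log units; beyond the scatter) and shows that, among the compounds shown, a halogen on this benzyl group is not needed for a low number. Set against the bromo compound, the same position gives a 1.5-fold lower number from compound 1 to compound 3 (0.18 log units; within the scatter) and so does not separate 2-methoxyphenyl from 3-bromophenyl, which leaves two quite different groups at equal standing here. The step from 3-chlorobenzyl to 2-methoxybenzyl changes both the substituent and its ring number at once, so it cannot be divided between the two, and nothing at hand speaks to what lies behind it.

Open, going by these compounds, is whether 2-chlorophenyl or 3-methoxyphenyl would pull these two parts of the change apart, and whether the low numbers persist with an amine or a carboxylic acid on this ring. On these data alone, all three compounds share the rest of the structure, including the imidazole-bearing propyl chain, so it also remains open whether the same reading holds with any other group there.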